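The source may hold more compounds than are shown below. What is called first, only, known or untested is meant among the compounds shown, and "the series" means these compounds.

Of the compounds shown here, three have been measured so far in a functional assay on DU-145 cells (Homo sapiens) for cytotoxicity, read by sulforhodamine B assay, with a stated time of 48 h, tested at 0.001 uM (a higher number here means a weaker effect of the compound at the concentration tested, a lower number a stronger effect), and their numbers sit close together. Compound 1 `COc1cc(C)cc(-c2nn(CC#N)cc2-c2ccc(-c3cccc(C(C)=O)c3)nc2)c1` gives 110%. Compound 2 `Cc1cc(O)cc(-c2nn(CC#N)cc2-c2ccnc(-c3ccc(Oc4ccccc4)cc3)c2)c1` gives 104%. Compound 3 `COc1cc(C)cc(-c2nn(CC#N)cc2-c2ccnc(-c3ccc(N(C)C)cc3)c2)c1` gives 103%, the lowest of the three numbers, yet its gap to compound 2 and its gap to compound 1 both lie within the usual scatter, so these values do not tell the three apart.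

Compound 4 `Cc1cc(O)cc(-c2nn(CC#N)cc2-c2ccnc(-c3ccc(N(C)C)cc3)c2)c1` has not yet been measured in this assay. It differs from compound 3 in one place: hydrogen in place of methyl on an oxygen on an aromatic ring. For the measured compounds named here, no pair of measured compounds shows this change on its own, so no measured step can be borrowed. What the numbers do show is that the hydroxy form of the same ring appears in compound 2, whose value of 104% lies within the scatter of compound 3. On that basis the step of a number 1 percentage points higher from compound 3 to compound 4 (within the scatter) is expected to be small, with no direction beyond the scatter. Compound 4 is estimated at 104%, within a range from 92% to 116%.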

Compound 4, a percentage reported as activity, at one concentration (the size of the read-out at that concentration, not a potency): 103%
Beside the measured number, compound 4's estimate is 1 percentage points above it; measured number inside the range.
By their numbers in this assay, from the lowest: compounds 3, 4, 2 and 1 (each within the scatter of the next).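

In this assay, the change from methoxy to hydroxy on the 3-methoxy-5-methylphenyl group now stands alone in one pair, and it gives no change at the digits printed from compound 3 to compound 4 (within the scatter). For the compounds shown here, a second place can also be read for the first time: dimethylamino in place of phenoxy on an aromatic carbon gives a number 1 percentage points lower from compound 2 to compound 4 (within the scatter), so neither single change separates its pair at this concentration. No supporting measurement is available that could explain these two results.

With every value taken at one low concentration, the compounds shown leave open whether either change would separate its pair at a concentration where the cells respond. They also leave open whether an ethoxy group on that oxygen, or an amine or a carboxylic acid in place of the dimethylamino group, would give a number beyond the scatter.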